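The compounds below may be only part of what the source reports. "The series", "measured", "known", "first", "only" and "open" are said of these compounds alone.

Compound 1 `CC(C)(C)c1ccc(Cn2nc(-c3ccc(Cl)cc3)cc2C(=N)NO)cc1` is the weakest point of the present set: in a functional assay on NCI-H23 cells (Homo sapiens) for antiproliferative activity, read by BrdU incorporation, with a stated time of 48 h (a lower number here means a stronger inhibitor, a higher number a weaker inhibitor), compound 1 gives 12300 nM. Compound 2 `CC(C)(C)c1ccc(Cn2nc(-c3ccc(Cl)cc3)cc2C(=O)N/N=C/c2cccc(O)c2O)cc1` carries an acylhydrazone bearing a 2,3-dihydroxyphenyl group in place of the amidoxime, and in this assay compound 2 gives 300 nM. Compound 3 `O=C(N/N=C/c1cccc(O)c1O)c1cc(-c2ccc(Cl)cc2)nn1Cc1ccc(Cl)nc1` keeps that acylhydrazone but has 6-chloropyridin-3-yl in place of 4-(tert-butyl)phenyl on the saturated chain carbon bound to the aromatic nitrogen; in this assay compound 3 gives 570 nM. That exchange produced a 1.9-fold higher number from compound 2 to compound 3 (0.28 log units; within the scatter), so compound 3 stands second of the three numbers, close to compound 2 and far from compound 1.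

Compound 4 `O=C(N/N=C/c1ccccc1O)c1cc(-c2ccc(Cl)cc2)nn1Cc1ccc(Cl)nc1` is the next step. It differs from compound 3 by hydrogen in place of hydroxy on an aromatic carbon. Among the measured compounds shown here, none of the measured steps touches this position, so no step bears directly on it; the only measured step, from compound 2 to compound 3, concerns a different part of the molecule and stayed within the scatter. With no guidance from the data, a small weakening at most is expected, a 1.8-fold higher number from compound 3 to compound 4 (0.24 log units; within the scatter), which may itself fall within the scatter. Compound 4 is therefore estimated at 1000 nM in this assay, with a range from 400 nM to 3000 nM.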

Compound 4, half-maximal inhibitory concentration: 270 nM
Beside the measured number, compound 4's estimate is 3.7-fold (0.57 log units) above it; measured number below the stated range.
By their numbers in this assay, from the lowest: compounds 4, 2 and 3 (each within the scatter of the next, the first and the last beyond it); then compound 1.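

Taking away one hydroxy group, so that 2,3-dihydroxyphenyl becomes 2-hydroxyphenyl, gave in this assay a 2.1-fold lower number from compound 3 to compound 4 (0.32 log units; beyond the scatter), a modest step that lies just beyond the usual scatter. Among the compounds shown here, this is the first measured change on this aromatic ring, and it shows that, with the rest of compound 3 held fixed, the hydroxy group at this position is not required for antiproliferative activity, since plain hydrogen does at least as well there. The data give no measured property that would explain this gain, so the reason for it remains unknown.

The compounds shown leave open whether a group other than hydrogen, such as methoxy, fluorine or an amine, would do better or worse at this position on the ring, and whether the hydroxy group that remains in 2-hydroxyphenyl matters on its own. They also leave open whether the same exchange would give a similar step with 4-(tert-butyl)phenyl in place of 6-chloropyridin-3-yl, as only the 6-chloropyridin-3-yl pair carries this change.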